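Shortening the linker to a hydroxyphenyl urea

This account rests on a few compounds, and the source may have more. Where it says the series, first, only, none or still open, it means among the compounds named here.

Compound 1 `COc1cc(NC(C)CCCNC(=O)NNC(=O)Nc2ccc(Cl)cc2)c2ncccc2c1` gives 48000 nM in a functional assay on SW-620 cells (Homo sapiens) for inhibition, read by MTT assay, with a stated time of 72 h (on this read-out higher numbers stand for weaker inhibition and lower numbers for stronger inhibition), the highest of the two numbers; compound 2 `COc1cc(NC(C)CCCNC(=O)Nc2cc(C(F)(F)F)cc(C(F)(F)F)c2)c2ncccc2c1` gives 3900 nM. Compound 3 `COc1cc(NC(C)CCCNC(=O)NNC(=O)Nc2ccc(O)cc2)c2ncccc2c1` reaches only a limit of this assay at > 100000 nM. The step of an at least 2.0-fold higher number from compound 1 to compound 3 (0.31 log units; beyond the scatter) shows that a hydroxy in place of chloro weakens inhibition, though its size is capped by the limit of > 100000 nM in this assay, at which 1 of the 3 values shown sits. Compound 4 `COc1cc(NC(C)CCCNC(=O)Nc2ccc(O)cc2)c2ncccc2c1` differs from compound 1 by 4-hydroxyphenyl in place of ((4-chlorophenyl)carbamoyl)amino on an amide-type nitrogen. Among the measured compounds shown here, the change brings compound 4 close to compound 2 in shape but carries the hydroxy of compound 3, and compound 1 and compound 2 have no single shared step to guide it. The author therefore expects compound 4 to give 30000 nM, within 8000 nM to 100000 nM, a step of a 1.6-fold lower number from compound 1 to compound 4 (0.20 log units; within the scatter) estimated as little beyond the scatter.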

Compound 4, half-maximal inhibitory concentration: 30000 nM
Compound 4: the middle estimate sits on the measured number at the digits printed, within the range that was stated.
By their numbers in this assay, from the lowest: compound 2; then compounds 4 and 1 (each within the scatter of the next). At a limit, above all of these: compound 3.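

With the hydroxy kept, 4-hydroxyphenyl in place of ((4-hydroxyphenyl)carbamoyl)amino on the amide-type nitrogen gives an at least 3.3-fold lower number from compound 3 to compound 4 (0.52 log units; beyond the scatter) in this assay, so at this position the shorter urea restores a readable number. The chlorinated compound shows no such gain, with a 1.6-fold lower number from compound 1 to compound 4 (0.20 log units; within the scatter), so the same kind of exchange is not separable from the scatter there. The first step has only a lower bound, set by compound 3: the limit of > 100000 nM in this assay, at which 1 of the 4 values shown sits.

As far as these compounds go, what remains open is how the number would respond to a carboxylic acid or an amine in place of the hydroxy of compound 4.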